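The compounds below may be only part of what the source reports. "The series", "measured", "known", "first", "only" and "open" are said of these compounds alone.

Measured compounds:
compound 1, `COc1cc(OC)c2sc(-c3ccc(N/C=C\C(=O)c4ccc(OC)c(O)c4)cc3)nc2c1`, in a functional assay on MDA-MB-231 cells (Homo sapiens) for antiproliferative activity, read by sulforhodamine B assay, with a stated time of 48 h (on this read-out higher numbers stand for weaker inhibition and lower numbers for stronger inhibition), compound 1 gives 7610 nM
compound 2, `COc1cc(OC)c2sc(-c3ccc(N/C=C\C(=O)c4ccc(OC)c([N+](=O)[O-])c4)cc3)nc2c1`, compound 2 gives 12900 nM
compound 3, `COc1ccc2nc(-c3ccc(N/C=C\C(=O)c4ccc(OC)c(O)c4)cc3)sc2c1`, compound 3 gives 18900 nM

Compounds 1 and 2 share a core and differ by a single change, (nitro in place of hydroxy on an aromatic carbon). The measured step of a 1.7-fold higher number from compound 1 to compound 2 (0.23 log units; within the scatter) shows that this exchange left the read-out essentially where it was.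

Compound 3 carries a different core from compound 1; the difference between the two cores is not broken down here. Of the three numbers, that of compound 3 is the highest, but it lies within the scatter of compound 2. Only compound 1 gives a number that is lower than that of compound 3 by more than the scatter.

Compound 4, `COc1ccc2nc(-c3ccc(N/C=C\C(=O)c4ccc(OC)c([N+](=O)[O-])c4)cc3)sc2c1`, has not yet been measured in this assay. It differs from compound 3 by nitro in place of hydroxy on an aromatic carbon, which is the same change as that from compound 1 to compound 2, made at the same place. Because the earlier step of a 1.7-fold higher number from compound 1 to compound 2 (0.23 log units; within the scatter) stayed within the scatter, the step expected from compound 3 to compound 4 is also small, estimated as a 1.5-fold higher number from compound 3 to compound 4 (0.17 log units; within the scatter). Compound 4 is therefore expected to give about 28000 nM in this assay. The estimate for compound 4 is expected to fall between 12000 nM and 65000 nM, with some chance that so weak an effect is reported only as a limit.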

Compound 4, half-maximal inhibitory concentration: 17600 nM
Estimate against measurement, compound 4: 1.6-fold (0.20 log units) above, within the range that was stated.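

In this assay, exchanging the 3-hydroxy-4-methoxyphenyl group for 4-methoxy-3-nitrophenyl on the second core gave a 1.1-fold lower number from compound 3 to compound 4 (0.03 log units; within the scatter), so here too the read-out stayed essentially where it was. Set side by side, the steps on the two cores cannot be told apart, and the exchange reads the same on both: the same change on two cores in this assay, a 1.7-fold higher number (0.23 log units; within the scatter) from compound 1 to compound 2 and a 1.1-fold lower number (0.03 log units; within the scatter) from compound 3 to compound 4, 1.8-fold (0.26 log units) apart, within the scatter of two such steps. This shows that, for these two pairs, nitro in place of hydroxy carries from one core to the other with no measurable effect on the read-out, but it does not show that the same would hold on any further core or in any other assay, and with both steps this small, the pairs cannot show whether a larger effect of a change at this place would also carry across.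

The compounds shown hold only hydroxy or nitro at this place on the aromatic ring, which leaves open how an amine, a carboxylic acid or a fluorine there would read in this assay. Also open, on these data alone, is whether a longer chain in place of the methoxy group on that ring would shift the number on either core.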